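The source may hold more compounds than are shown below. What is called first, only, known or untested is meant among the compounds shown, and "the series" means these compounds.

Measured compounds:
- compound 1 `Cc1ccc(-c2nn(-c3ccccc3)cc2C(=O)NOCc2ccccc2F)cc1` — 2110 nM
- compound 2 `O=C(NOCc1ccccc1F)c1cn(-c2ccccc2)nc1-c1ccc(Cl)cc1` — 15100 nM

Going by the values given here, in a functional assay on MCF7 cells (Homo sapiens) for antiproliferative activity, read by MTT assay, with a stated time of 48 h, in the presence of a further agent that is not named here (on this read-out higher numbers stand for weaker inhibition of growth and lower numbers for stronger inhibition of growth), compound 2 gives 15100 nM, the higher of the two numbers measured so far. Among the compounds with values here, compound 1 gives 2110 nM, and the only measured step, a 7.2-fold higher number from compound 1 to compound 2 (0.85 log units; beyond the scatter), is the replacement of a methyl by a chloro on the same aromatic carbon.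

Compound 3 `O=C(NOCc1ccccc1F)c1cn(-c2ccccc2)nc1-c1ccc(F)cc1` is not yet measured. It differs from compound 2 by fluoro in place of chloro on an aromatic carbon. Within the data shown here, no measured pair shows a fluoro in place of a chloro at this position, so the only guide is the methyl-to-chloro step, a 7.2-fold higher number from compound 1 to compound 2 (0.85 log units; beyond the scatter), which tells that a change of this one group at this carbon can move the number in this assay well beyond the scatter. Which direction the halogen swap takes is not settled by the two values in hand.

Compound 3 is therefore expected to give about 7000 nM in this assay, between 1500 nM and 30000 nM, a step of a 2.2-fold lower number from compound 2 to compound 3 (0.33 log units; beyond the scatter) that is estimated with little confidence.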

Compound 3, concentration for 50% growth inhibition: 12000 nM
Compound 3: the middle estimate sits 1.7-fold (0.23 log units) below what was measured; measured number inside the range.
By their numbers in this assay, from the lowest: compound 1; then compounds 3 and 2 (each within the scatter of the next).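

In this assay, putting the 4-fluorophenyl in place of the 4-chlorophenyl gives a 1.3-fold lower number from compound 2 to compound 3 (0.10 log units; within the scatter), so on this read-out the two halogens cannot be told apart at this carbon, which the earlier pair, holding only one halogen, could not show. Fluoro in place of methyl gives a 5.7-fold higher number from compound 1 to compound 3 (0.75 log units; beyond the scatter), in the same direction as chloro in place of methyl, a 7.2-fold higher number from compound 1 to compound 2 (0.85 log units; beyond the scatter), and both steps lie beyond the scatter; among these three compounds, the divide at this position therefore runs between the methyl and the two halogens, not between the halogens themselves. Nothing available explains that divide.

Going by these compounds, it remains open whether the methyl stands alone or whether an ethyl, a methoxy group or an amine on this carbon would fall on its side or on that of the halogens. On these data alone, it is equally open whether a bromo would stay with the chloro and fluoro, and whether the divide would persist with a different group elsewhere on the shared core.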